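Trifluoromethyl for Fluoro on the Anilide of Compound 2

This account rests on a few compounds, and the source may have more. Where it says the series, first, only, none or still open, it means among the compounds named here.

Compound 1, `O=C(CN1CCN(c2nnc(Cc3ccncc3)c3ccccc23)CC1)Nc1ccc(F)c(F)c1`, gives 2320 nM in a functional assay on HT-29 cells (Homo sapiens) for cytotoxicity, read by MTT assay, with a stated time of 72 h; a higher number here means a weaker inhibitor, a lower number a stronger inhibitor.
Compound 2, `O=C(CN1CCN(c2nnc(Cc3ccccc3)c3ccccc23)CC1)Nc1ccc(F)c(F)c1`, gives 9510 nM in this assay.
Compound 3, `O=C(CN1CCN(c2nnc(Cc3ccncc3)c3ccccc23)CC1)Nc1cccc(Br)c1`, gives 1350 nM in this assay.

Compound 2 gives the highest number of the three; the step of a 4.1-fold higher number from compound 1 to compound 2 (0.61 log units; beyond the scatter) separates it from compound 1, and compound 3 gives the lowest number. Compound 4, `O=C(CN1CCN(c2nnc(Cc3ccccc3)c3ccccc23)CC1)Nc1ccc(F)c(C(F)(F)F)c1`, differs from compound 2 in one place: trifluoromethyl in place of fluoro on an aromatic carbon. For the measured compounds named here, the only measured step on that amide-type nitrogen, a 1.7-fold lower number from compound 1 to compound 3 (0.24 log units; within the scatter), stayed within the scatter, and no measured step exchanges fluoro for trifluoromethyl anywhere. The step of a 1.3-fold lower number from compound 2 to compound 4 (0.10 log units; within the scatter) is therefore expected to stay within the scatter, in either direction. In this assay compound 4 is estimated at 7500 nM, with a range from 2800 nM to 18000 nM.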

Compound 4, half-maximal inhibitory concentration: 4590 nM
Estimate against measurement, compound 4: 1.6-fold (0.21 log units) above, within the range that was stated.
By their numbers in this assay, from the lowest: compounds 3, 1 and 4 (each within the scatter of the next, the first and the last beyond it); then compound 2.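

In this assay the step of a 2.1-fold lower number from compound 2 to compound 4 (0.32 log units; beyond the scatter) shows that trifluoromethyl in place of fluoro on the anilide ring can move the number beyond the scatter, though only modestly. For the compounds shown here, the one earlier step on that amide-type nitrogen stayed within the scatter, so this is the only change there that exceeds it, and it lowers the number on the phenyl compound. Nothing given here accounts for the step.

From the compounds shown here alone, it remains open whether the same exchange holds on compound 1, which carries pyridin-4-yl, and whether a nitrile or a methoxy group on this carbon would lower the number further.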